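The source may report more compounds than this note shows. Statements on the series, on what has been measured and on what is new or still open speak of the compounds shown alone.

Compound 1 `O=C(NCc1ccc(S(=O)(=O)c2cccc(F)c2)cc1)c1cc2cnccc2[nH]1` was tested in an ADME assay on microsomes from liver (Mus musculus) for metabolic stability, read by LC-MS, with a stated time of 30 min, tested at 1 uM (a higher number here means that more of the compound is left, a lower number that less of the compound is left), and gave 44%. Of the two compounds for which a number was obtained, compound 1 stands lowest. The nearer of the others, compound 3 `O=C(NCc1ccc(S(=O)(=O)c2cc(F)cc(F)c2)cc1)c1cnc2nccn2c1`, gave 71% in this assay, a reading higher by a margin that lies beyond the scatter of repeated measurements; since the two structures differ in more than one place, their values are compared here without any step being drawn between them. Compound 2 `O=C(NCc1ccc(S(=O)(=O)N2CCCCC2)cc1)c1ccn2ccnc2c1` was entered in the series, but in this assay compound 2 shows "not determined" (no result reported), so it offers no number for comparison.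

The account now turns to compound 4 `O=C(NCc1ccc(S(=O)(=O)c2ccccc2)cc1)c1cc2cnccc2[nH]1`, which differs from compound 1 in a single place. hydrogen in place of fluoro on an aromatic carbon The difference, read one bond further out, is 3-fluorophenyl to phenyl.

Going by the values given here, no pair of measured compounds separated by this one change is available, so the size of the step has to be estimated from compound 1 alone. The author expects the step from compound 1 to compound 4 to be a number 6 percentage points lower from compound 1 to compound 4 (within the scatter), a shift not clearly beyond the scatter of this assay, and perhaps tending slightly downward. On that basis compound 4 is estimated to give 38% in this assay, within a range from 18% to 58%.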

Compound 4, percent of the compound remaining: 54%
Estimate against measurement, compound 4: 16 percentage points below; low and high end bracket the measured number.
By their numbers in this assay, from the lowest: compounds 1 and 4 (each within the scatter of the next); then compound 3.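

Replacing 3-fluorophenyl with phenyl gives the only single-place step among the compounds shown: in this assay, hydrogen in place of fluoro on an aromatic carbon, at a place meta to a large group, amounts to a number 10 percentage points higher from compound 1 to compound 4 (within the scatter) on the core of compound 1. With the rest of the structure held fixed, the fluoro at this position therefore makes no difference beyond the usual scatter of repeated measurements, something the comparison of compound 1 with compound 3 could not show, as those two differ in more than one place. No measurement at hand speaks to why the reading behaves this way, so the step stands as an observation only.

On these data alone, it remains open whether another group at this position, such as chloro, methoxy, a nitrile or an amine, would shift the reading in this assay beyond the scatter, or whether it would stay as close as this change does. As far as these compounds go, it is also open whether the same exchange of fluoro for hydrogen would behave alike on a different core, such as that of compound 3.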